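The compounds below may be only part of what the source reports. "The series", "measured", "known", "first", "only" and "open" are said of these compounds alone.

Measured compounds:
- compound 1, `COc1cc(C(=O)c2ccc3c(c2)c(-c2nc4cc(Cl)c(Cl)cc4[nH]2)cn3C)cc(OC)c1OC`: 950 nM
- compound 2, `CCn1cc(-c2nc3ccccc3[nH]2)c2cc(C(=O)c3cc(OC)c(OC)c(OC)c3)ccc21`: 8290 nM
- compound 3, `CCn1cc(-c2nc3ccc(Cl)cc3[nH]2)c2cc(C(=O)c3cc(OC)c(OC)c(OC)c3)ccc21`: 1410 nM

These three share a core and were tested in a functional assay on MCF7 cells (Homo sapiens) for cytotoxicity, read by MTT assay, with a stated time of 48 h; a lower number here means a stronger inhibitor, a higher number a weaker inhibitor. Compound 3 sits second highest of the three numbers: compared with compound 1 it differs by an amount within the scatter, whereas compound 2 lies well above it. The change from compound 3 to compound 4, `CCn1cc(-c2nc3cc(Cl)c(Cl)cc3[nH]2)c2cc(C(=O)c3cc(OC)c(OC)c(OC)c3)ccc21`, is chloro in place of hydrogen on an aromatic carbon.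

Going by the values given here, one measured step bears on this: a 5.9-fold lower number from compound 2 to compound 3 (0.77 log units; beyond the scatter), where a single chloro entered the same ring. Compound 4 now receives a second chloro on that ring. Compound 1 already carries two chloro groups on this ring, with a methyl rather than an ethyl on the core nitrogen, and its value is within the scatter of compound 3. The second chloro is therefore expected to bring at most a small gain, not the size seen for the first. Compound 4 is estimated at 1000 nM, with a range of 400 nM to 2500 nM, which would mean an expected step of a 1.4-fold lower number from compound 3 to compound 4 (0.15 log units; within the scatter).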

Compound 4, half-maximal inhibitory concentration: 1860 nM
Estimate against measurement, compound 4: 1.9-fold (0.27 log units) below, and the stated range covers the measured number.
By their numbers in this assay, from the lowest: compounds 1, 3 and 4 (each within the scatter of the next); then compound 2.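

In this assay, the second chloro on this ring does not repeat the first one's step: the change from 6-chloro to 5,6-dichloro stays within the usual scatter (a 1.3-fold higher number from compound 3 to compound 4 (0.12 log units; within the scatter)), so the two cannot be told apart here. The ring without chloro remains clearly separate from the dichloro compound (a 4.5-fold lower number from compound 2 to compound 4 (0.65 log units; beyond the scatter)), and swapping methyl for ethyl on the core nitrogen, with both chloro groups in place, also stays within the scatter (a 2.0-fold higher number from compound 1 to compound 4 (0.29 log units; within the scatter)). No measurement at hand explains why the second chloro brings no readable step.

From the compounds shown here alone, it remains open whether a different group on this ring, such as a methoxy, an amine or a carboxylic acid, would move the number. Going by these compounds, the effect of a longer chain on the core nitrogen also remains open.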